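A few compounds are considered here, and "the series" means these few. Any claim that something is new, unique, unknown or untested is made for them only; others in the source may bear on it.

Measured compounds in an assay for inhibition of kynurenine 3-monooxygenase (Homo sapiens), read by mass spectrometry, with a stated time of 1 h; on this read-out lower numbers stand for stronger inhibition and higher numbers for weaker inhibition:
compound 1, `C[C@@H](Oc1cc2oc(=O)n(CCC(=O)O)c2cc1Cl)c1cccnn1`, 1.26 nM;
compound 2, `C[C@@H](Oc1cc2oc(=O)n(CCC(=O)O)c2cc1Cl)c1ccc(Cl)cn1`, 3.16 nM;
compound 3, `CCOc1cc2oc(=O)n(CCC(=O)O)c2cc1Cl`, 5.01 nM.

Compound 3 stands at the highest of the three numbers. The step of a 4.0-fold higher number from compound 1 to compound 3 (0.60 log units; beyond the scatter) is a change beyond the scatter, whereas the step of a 1.6-fold higher number from compound 2 to compound 3 (0.20 log units; within the scatter) stays within it. Compound 4, `Cc1cccc([C@@H](C)Oc2cc3oc(=O)n(CCC(=O)O)c3cc2Cl)n1`, differs from compound 3 by 6-methylpyridin-2-yl in place of hydrogen on a saturated chain carbon bound to an oxygen on an aromatic ring and a saturated chain carbon. That change runs opposite to the two steps in which an aromatic group gave way to hydrogen, so compound 4 is expected to show a lower number than compound 3, a step of a 2.5-fold lower number from compound 3 to compound 4 (0.40 log units; beyond the scatter). Compound 4 is therefore estimated at 2 nM in this assay, with a range from 0.8 nM to 5 nM.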

Compound 4, half-maximal inhibitory concentration: 5.01 nM
Estimate against measurement, compound 4: 2.5-fold (0.40 log units) below, and the stated range ends below it.
By their numbers in this assay, from the lowest: compound 1; then compounds 2, 3 and 4 (each within the scatter of the next).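

In this assay the entry of 6-methylpyridin-2-yl at this position gives no change at the digits printed from compound 3 to compound 4 (within the scatter), so here an aromatic group in place of hydrogen brings no gain. Exchanging 5-chloropyridin-2-yl for 6-methylpyridin-2-yl gives a 1.6-fold higher number from compound 2 to compound 4 (0.20 log units; within the scatter), while exchanging pyridazin-3-yl for it gives a 4.0-fold higher number from compound 1 to compound 4 (0.60 log units; beyond the scatter), which leaves compound 1 as the only one of the series set apart beyond the scatter. No evidence is available that bears on this result. The compounds shown leave open how an unsubstituted pyridin-2-yl or a phenyl ring would read at this position. They also leave open whether a saturated amine there would stand with compound 1 or with compound 4.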